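Methoxy on the Thiazole-Linked Phenyl: Two Cores Compared

The source may hold more compounds than are shown below. What is called first, only, known or untested is meant among the compounds shown, and "the series" means these compounds.

Measured compounds in a functional assay on U-87MG ATCC cells for antiproliferative activity against U-87 MG (Homo sapiens), read by MTT assay, with a stated time of 48 h, tested at 5 uM; on this read-out lower numbers stand for a stronger effect and higher numbers for a weaker effect at the one concentration tested:
compound 1 `COc1ccc(-c2nc(C)c(C(=O)CSc3nc(N)c(C#N)c(-c4ccccc4)n3)s2)cc1` gives 61.8%
compound 2 `Cc1nc(-c2ccccc2)sc1C(=O)CSc1nc(-c2ccc(Cl)c(Cl)c2)c(C#N)c(=O)[nH]1` gives 98.6%
compound 3 `Cc1nc(-c2ccccc2)sc1C(=O)CSc1nc(N)c(C#N)c(-c2ccccc2)n1` gives 103%

Compound 3 and compound 1 share one core and differ in a single place: methoxy in place of hydrogen on an aromatic carbon. That change produced a large step, a number 41.2 percentage points lower from compound 3 to compound 1 (beyond the scatter), so compound 1 stands well apart from compound 3 in this assay. Compound 2 carries a different core; the difference between the two cores is not broken down here. In this assay compound 2 gives 98.6%, and compound 3 gives 103%, two numbers that lie within the usual scatter of each other, so no order between them can be claimed.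

Compound 4 `COc1ccc(-c2nc(C)c(C(=O)CSc3nc(-c4ccc(Cl)c(Cl)c4)c(C#N)c(=O)[nH]3)s2)cc1` has not yet been measured. It differs from compound 2 by methoxy in place of hydrogen on an aromatic carbon, the same change, at the same kind of place, that separates compound 3 from compound 1. Among the compounds with values here, the only measured example of that change is the step from compound 3 to compound 1, observed on a different core. Within the data shown here, because the step of a number 41.2 percentage points lower from compound 3 to compound 1 (beyond the scatter) was large, a drop from compound 2 to compound 4 is expected, but with only one precedent and an unbroken-down difference between the cores, the expected step is set somewhat smaller: a number 26.6 percentage points lower from compound 2 to compound 4 (beyond the scatter). Compound 4 is therefore estimated at 72% in this assay, with a range from 48% to 96% that reflects the uncertainty of carrying one observed step across to another core.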

Compound 4, a percentage reported as activity, at one concentration (the size of the read-out at that concentration, not a potency): 101%
The estimate for compound 4 lay 29 percentage points below the measured number; measured number above the stated range.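

In this assay, the change from phenyl to 4-methoxyphenyl did not repeat on the core of compound 2, where the step reads a number 2.4 percentage points higher from compound 2 to compound 4 (within the scatter) and so shows no change that can be claimed. Set beside the earlier example, the same change gave two different results on the two cores: the same change on two cores in this assay, a number 41.2 percentage points lower (beyond the scatter) from compound 3 to compound 1 and a number 2.4 percentage points higher (within the scatter) from compound 2 to compound 4, 43.6 percentage points apart, beyond the scatter of two such steps. Within the data shown here, this shows that, in this series, a step seen for methoxy on one core cannot simply be carried to the other, but it rests on only two pairs of compounds, so it gives no general rule and does not show which of the differences between the two cores accounts for the gap.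

The compounds shown leave open whether a chlorine, a hydroxyl or an amine in place of the methoxy would follow the step seen on the core of compound 1 or the one seen on the core of compound 2. They also leave open which part of the core of compound 2 sets it apart, since no compound shown changes the core's groups one at a time while keeping the 4-methoxyphenyl in place.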